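The source may hold more compounds than are shown below. What is called first, only, known or untested is meant among the compounds shown, and "the series" means these compounds.

Measured so far:
- Compound 1 `O=C(C1CCN(c2ccncn2)CC1)N1N=CC[C@H]1c1ccccc1`: 3.2
- Compound 2 `Cc1nnc(N2CCC(C(=O)N3N=CC[C@H]3c3cc(F)cc(F)c3)CC2)o1`: 3.6
- Compound 3 `CCC(=O)N1CCC(C(=O)N2N=CCC2c2ccccc2)CC1`: 3.2

In a physicochemical assay for lipophilicity, read by HPLC, measured as chromatographic lipophilicity, at pH 7.4 (on this read-out lower numbers stand for lower lipophilicity and higher numbers for higher lipophilicity), compound 1 stands level with compound 3 at the digits shown, the two together being the lowest of the three numbers, while compound 2 reads higher by an amount beyond the usual scatter. Compound 4 `CC(=O)N1CCC(C(=O)N2N=CC[C@H]2c2ccccc2)CC1` has not yet been measured. It differs from compound 1 in one place: acetyl in place of pyrimidin-4-yl on an amine nitrogen in a ring. Among the compounds with values here, no measured pair shows this step directly, so the size is estimated rather than known. A small drop in this assay, within the scatter, is expected, the step of a number 0.20 log units lower from compound 1 to compound 4 (within the scatter) being the estimate, because compound 3 gives 3.2 with a closely related structure. Compound 4 is therefore expected to reach about 3, between 2.6 and 3.4.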

Compound 4, distribution coefficient: 2.5
For compound 4 the middle estimate is 0.50 log units above the measured one; measured number below the stated range.
By their numbers in this assay, from the lowest: compound 4; then compounds 1 and 3 (each within the scatter of the next); then compound 2.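

Within the data shown here, this is the first direct reading of a change on the amine nitrogen in the ring: in this assay, acetyl in place of pyrimidin-4-yl gives a number 0.70 log units lower from compound 1 to compound 4 (beyond the scatter) and so moves the read-out by more than repeat measurements would. The change swaps a six-membered aromatic ring for a smaller group with no ring. No measurement here explains the drop.

Still open, from the compounds shown here alone, is whether losing the ring or gaining the carbonyl matters more. A plain methyl or a benzoyl group on the same nitrogen would help separate the two.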